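Swapping the Nitrogen Substituent on a Styryl Sulfone

This account rests on a few compounds, and the source may have more. Where it says the series, first, only, none or still open, it means among the compounds named here.

In a functional assay on DU-145 cells (Homo sapiens) for cytotoxicity, read by trypan blue exclusion, with a stated time of 96 h (on this read-out lower numbers stand for stronger inhibition and higher numbers for weaker inhibition), compound 3 (`COC(=O)C(F)(F)Nc1cc(CS(=O)(=O)/C=C/c2c(OC)cc(OC)cc2OC)ccc1OC`) gives 250 nM, the lowest of three numbers, against compound 1 (`COc1ccc(OC)c(/C=C/S(=O)(=O)Cc2ccc(OC)c(N)c2)c1`) at 750 nM and compound 2 (`COc1cc(OC)c(/C=C/S(=O)(=O)Cc2ccc(OC)c([N+](=O)[O-])c2)c(OC)c1`) at 2500 nM. Compound 4 (`COC(=O)C(Nc1cc(CS(=O)(=O)/C=C/c2c(OC)cc(OC)cc2OC)ccc1OC)c1ccc(Cl)cc1`) carries (4-chlorophenyl)(methoxycarbonyl)methyl in place of difluoro(methoxycarbonyl)methyl on a nitrogen on an aromatic ring. Among the compounds with values here, the only measured step at this part of the molecule is a 10-fold lower number from compound 2 to compound 3 (1.00 log units; beyond the scatter), where (difluoro(methoxycarbonyl)methyl)amino replaced nitro. Within the data shown here, that shows this site can move the number, but no measured step swaps one nitrogen substituent for another, so no shift beyond the scatter is expected. The expected step is no change at the digits printed from compound 3 to compound 4 (within the scatter). For compound 4 the estimated value is 250 nM, with an expected range from 70 nM to 900 nM.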

Compound 4, half-maximal inhibitory concentration: 400 nM
Estimate against measurement, compound 4: 1.6-fold (0.20 log units) below; the range from low to high includes it.
By their numbers in this assay, from the lowest: compounds 3, 4 and 1 (each within the scatter of the next, the first and the last beyond it); then compound 2.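

In this assay, swapping one nitrogen substituent for another gives a 1.6-fold higher number from compound 3 to compound 4 (0.20 log units; within the scatter), even though the entering (4-chlorophenyl)(methoxycarbonyl)methyl adds an aromatic ring and more heavy atoms than difluoro(methoxycarbonyl)methyl. The earlier compounds shown here showed only that replacing nitro could move the number; this pair shows that the group on this nitrogen can change greatly with no difference beyond the scatter. No measurement at hand accounts for this result. From the compounds shown here alone, both groups carry the methyl ester, so its role remains open. A carboxylic acid in its place, or a plain methyl on the nitrogen, would address that.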